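Replacing a Fluoro with Hydrogen on Compound 3

The source may report more compounds than this note shows. Statements on the series, on what has been measured and on what is new or still open speak of the compounds shown alone.

Measured so far in an in vitro ADME assay on microsomes from liver (Homo sapiens) for metabolic stability, tested at 1 uM; a lower number here means that the compound disappears faster, a higher number that the compound lasts longer:
Compound 1 (`COc1cc(-c2cc(-c3ccc(S(C)(=O)=O)cc3)cnc2N)ccc1O`) gives 1.72 h
Compound 2 (`COc1ccc(-c2cc(-c3ccc(S(C)(=O)=O)cc3)cnc2N)cn1`) gives > 1.65 h, a limit of the assay and not a number
Compound 3 (`CS(=O)(=O)c1ccc(-c2cnc(N)c(-c3ccc(C(F)(F)F)c(F)c3)c2)cc1`) gives 2.05 h

Only two of these three results are actual numbers. Compound 3, with a half-life of 2.05 h, lies within the scatter of compound 1 at 1.72 h. The result for compound 2 remains a limit and cannot be placed against them.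

Compound 4 (`CS(=O)(=O)c1ccc(-c2cnc(N)c(-c3ccc(C(F)(F)F)cc3)c2)cc1`) is reached from compound 3 by one change: hydrogen in place of fluoro on an aromatic carbon. Hydrogen stands in place of fluoro on an aromatic carbon, ortho to a trifluoromethyl group and meta to a large group. Within the data shown here, no pair of measured compounds differs in one place only, so the data offer no direct measure of what this exchange does in this assay. The expectation therefore starts from compound 3 at 2.05 h and allows for a wide range. No change beyond the scatter is expected, and the estimated step is a 1.1-fold lower number from compound 3 to compound 4 (0.03 log units; within the scatter). For compound 4 the expected half-life is 1.9 h, with an estimated range from 1 h to 3.5 h.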

Compound 4, half-life: > 4.16 h
Compound 4: a limit, no number (the forecaster's own chance of this, stated with the estimate: 15%); at least 2.1-fold (0.34 log units) between middle value and limit.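

Hydrogen in place of fluoro on an aromatic carbon, ortho to a trifluoromethyl group, gives the first exchange in this set that can be read in one place, with an at least 2.0-fold higher number from compound 3 to compound 4 (0.30 log units; that floor lies within the scatter). In this assay compound 4 gives > 4.16 h, a limit of the assay and not a number. The floor of the step lies within the scatter, so the pair does not by itself establish a change beyond it, yet it does show that this fluoro is not required for the half-life seen with compound 3, since losing it brings no drop in this read-out and leaves room for a larger rise.

How far the half-life of compound 4 actually reaches stays open, and so does any reason for the step, since the pair gives only its floor. Also open, from the compounds shown here alone, is whether a chloro, a nitrile or an amine on this same carbon would follow hydrogen or fluoro, and whether the exchange would hold with a group other than trifluoromethyl ortho to it, such as a methyl or a longer chain.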